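Amide-nitrogen substituent and HeLa cell inhibition: working notes

This account rests on a few compounds, and the source may have more. Where it says the series, first, only, none or still open, it means among the compounds named here.

Measured so far:
compound 1 `COc1ccc2c(=O)c(/C=C/C(=O)Nc3ccccc3)coc2c1`: > 100000 nM (a limit of the assay)
compound 2 `COc1ccc2c(=O)c(/C=C/C(=O)Nc3ccccc3Cl)coc2c1`: 22400 nM
compound 3 `COc1ccc2c(=O)c(/C=C/C(=O)NCc3ccccc3F)coc2c1`: > 100000 nM (a limit of the assay)

In a functional assay on HeLa cells (Homo sapiens) for inhibition, read by MTT assay, with a stated time of 48 h (on this read-out higher numbers stand for weaker inhibition and lower numbers for stronger inhibition), compound 3 shows only a limit and no number. The same is true of compound 1, so the limit of > 100000 nM in this assay, at which 2 of the 3 values shown sit, marks where two of the three values rest. Going by the values given here, compound 2 is the only compound with a read number; the step of an at least 4.4-fold lower number from compound 1 to compound 2 (0.64 log units; beyond the scatter) is beyond the scatter, while a step that the two limits leave unreadable from compound 1 to compound 3 cannot be sized and an at least 4.4-fold higher number from compound 2 to compound 3 (0.64 log units; beyond the scatter) runs back up to the limit.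

Compound 4 `COc1ccc2c(=O)c(/C=C/C(=O)Nc3ccccc3OC)coc2c1` arises from compound 3 by 2-methoxyphenyl in place of 2-fluorobenzyl on an amide-type nitrogen. This returns the amide nitrogen to a directly attached phenyl ring carrying a single substituent, the arrangement found in compound 2, rather than the benzyl arrangement of compound 3. Among the compounds with values here, the only directly bearing steps are an at least 4.4-fold lower number from compound 1 to compound 2 (0.64 log units; beyond the scatter) and an at least 4.4-fold higher number from compound 2 to compound 3 (0.64 log units; beyond the scatter), both at least modest, and both pointing toward a lower number for a substituted phenyl on the amide nitrogen than for the benzyl of compound 3. A downward step is therefore expected, of size an at least 2.5-fold lower number from compound 3 to compound 4 (0.39 log units; beyond the scatter), though the limit of compound 3 leaves its true size uncertain. Compound 4 is estimated at 40000 nM, between 12000 nM and 100000 nM.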

Compound 4, half-maximal inhibitory concentration: > 100000 nM
Compound 4 gave a limit, no number; the forecaster's own chance of this, stated with the estimate: 35%; middle value at least 2.5-fold (0.39 log units) from the limit.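

In this assay compound 4 gives a limit of the assay and no number, and this is now the most common reading in the series: the limit of > 100000 nM in this assay, at which 3 of the 4 values shown sit.

Methoxy in place of chloro on the aromatic carbon is an at least 4.4-fold higher number from compound 2 to compound 4 (0.64 log units; beyond the scatter), so a directly attached phenyl ring carrying a single substituent does not by itself yield a read number; compound 2 remains the only compound with one, and compound 4 goes against any pattern that would cover such substituted phenyl rings in general. The steps joining compound 4 to the other two compounds at the limit cannot be read, so the change from the 2-fluorobenzyl to the 2-methoxyphenyl group has no measurable size here.

On these data alone, with a single read value, it remains open whether the reading of compound 2 is particular to chloro or is shared by another group on the same aromatic carbon, such as bromo, methyl or trifluoromethyl. As far as these compounds go, how far compound 1, compound 3 and compound 4 differ from one another beyond the limit also remains open, as does the outcome of an amine or a carboxylic acid on that phenyl ring.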